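Moving from the acid side chain to a hydroxyurea

The source may report more compounds than this note shows. Statements on the series, on what has been measured and on what is new or still open speak of the compounds shown alone.

Among the three compounds measured so far, compound 2, `CC(C)c1ccc2c(c1)c(SC(C)(C)C)c(CC(C)(C)/C=N/OCC(=O)O)n2Cc1ccc(Cl)cc1`, has the highest number in a functional assay on the whole organism (Peritoneal cavity) with Rattus norvegicus as the target (a higher number here means that more compound is needed for the effect, a lower number that less compound is needed), giving 3 umol/kg. Its nearest neighbour is compound 1, `CC(C)(/C=N/OCC(=O)O)Cc1c(SC(C)(C)C)c2cc(OCc3cccc(Cl)n3)ccc2n1Cc1ccc(Cl)cc1`, which in this assay gives 2.6 umol/kg; the step of a 1.2-fold higher number from compound 1 to compound 2 (0.06 log units; within the scatter) lies within the scatter. The furthest is compound 3, `CC(C)(/C=N/OCC(=O)O)Cc1c(SC(C)(C)C)c2cc(OCc3ccc4ccccc4n3)ccc2n1Cc1ccc(Cl)cc1`, which gives 0.24 umol/kg; the step of a 13-fold lower number from compound 2 to compound 3 (1.10 log units; beyond the scatter) is large, as is an 11-fold lower number from compound 1 to compound 3 (1.03 log units; beyond the scatter).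

Compound 4, `CC(C)c1ccc2c(c1)c(SC(C)(C)C)c(CC(C)(C)CN(O)C(N)=O)n2Cc1ccc(Cl)cc1`, differs from compound 2 in the chain, not on the ring: a group of 6 heavy atoms (2 carbon, 2 nitrogen, 2 oxygen; no ring) in place of a group of 7 heavy atoms (3 carbon, 1 nitrogen, 3 oxygen; no ring), on a saturated chain carbon bound to three saturated chain carbons. Every measured step changes a group on an aromatic carbon, so none of them bears on this exchange, and the data give no measured guide to its size or direction.

Compound 4 is therefore expected to give about 3 umol/kg, with a wide range from 0.6 umol/kg to 15 umol/kg. The estimated step of no change at the digits printed from compound 2 to compound 4 (within the scatter) is one of no change beyond the scatter, with the uncertainty spread to both sides.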

Compound 4, dose for half-maximal effect: 46 umol/kg
For compound 4 the middle estimate is 15-fold (1.19 log units) below the measured one; the whole stated range lies below it.
By their numbers in this assay, from the lowest: compound 3; then compounds 1 and 2 (each within the scatter of the next); then compound 4.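

With the rest of the molecule unchanged, the end of the chain matters in this assay: placing (carbamoyl(hydroxy)amino)methyl on the saturated chain carbon bound to three saturated chain carbons gives a 15-fold higher number from compound 2 to compound 4 (1.19 log units; beyond the scatter), so far more compound is needed for the effect. The earlier compounds shown here showed only changes on an aromatic carbon, and this chain exchange is of similar size to a 13-fold lower number from compound 2 to compound 3 (1.10 log units; beyond the scatter), but runs in the opposite direction. Nothing measured here accounts for this step.

As far as these compounds go, it remains open whether (quinolin-2-yl)methoxy on the aromatic carbon would lower the number for a compound that carries the new chain as well. From the compounds shown here alone, it is also open how a tetrazole or a primary amide at the end of the chain would compare.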